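This account rests on a few compounds, and the source may have more. Where it says the series, first, only, none or still open, it means among the compounds named here.

Compound 1 `COc1ccc(Cn2cc(/C=N\NC(=O)c3c[nH]c4ccc(Br)cc34)c3cc(OC)ccc32)cc1`, compound 2 `COc1ccc2c(c1)c(/C=N\NC(=O)c1c[nH]c3ccc(Br)cc13)cn2Cc1ccc(Cl)cc1` and compound 3 `COc1ccc(Cn2cc(/C=N\NC(=O)c3c[nH]c4ccc(Br)cc34)c3ccc(F)cc32)cc1` share a common core and were all tested in a functional assay on DU-145 cells (Homo sapiens) for cytotoxicity; a lower number here means a stronger inhibitor, a higher number a weaker inhibitor. In this assay compound 1 gives 84400 nM, compound 2 gives 57000 nM and compound 3 gives 67500 nM. All three numbers lie within the usual scatter of one another, so none of the three can be set above or below the others. Compound 2 differs from compound 1 in a single place, (chloro in place of methoxy on an aromatic carbon), and that change made the step of a 1.5-fold lower number from compound 1 to compound 2 (0.17 log units; within the scatter). Compound 4 `O=C(N/N=C\c1cn(Cc2ccc(Cl)cc2)c2cc(F)ccc12)c1c[nH]c2ccc(Br)cc12` has not yet been measured. It differs from compound 3 by the same change, (chloro in place of methoxy on an aromatic carbon), at a place described in the same way. How the core of compound 3 differs from the core of compound 1 is not broken down here. Because a 1.5-fold lower number from compound 1 to compound 2 (0.17 log units; within the scatter) stayed within the scatter, the step expected for compound 4 is a 1.4-fold lower number from compound 3 to compound 4 (0.15 log units; within the scatter). Compound 4 is therefore estimated to give about 48000 nM in this assay, most likely between 25000 nM and 95000 nM.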

Compound 4, half-maximal inhibitory concentration: 12500 nM
Beside the measured number, compound 4's estimate is 3.8-fold (0.58 log units) above it; measured number outside the range, below it.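

In this assay, replacing methoxy with chloro, which turns the 4-methoxybenzyl group into a 4-chlorobenzyl group, gave a 5.4-fold lower number from compound 3 to compound 4 (0.73 log units; beyond the scatter). The same change therefore did not carry over with the same size from one core to the other: the same change on two cores in this assay, a 1.5-fold lower number (0.17 log units; within the scatter) from compound 1 to compound 2 and a 5.4-fold lower number (0.73 log units; beyond the scatter) from compound 3 to compound 4, 3.6-fold (0.56 log units) apart, beyond the scatter of two such steps. This shows that a step measured on one core of this series cannot simply be copied onto another, but it does not show why the two steps differ, and two pairs of compounds cannot predict the size of the step on a third core.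

The compounds shown leave open which part of the difference between the two cores goes with the larger step. On these data alone, it also remains open how an amine or a carboxylic acid in place of the chloro would read on either core, since only methoxy and chloro are compared at this place.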